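Methyl in place of hydrogen: expected Vero cytotoxicity of compound 4

The source may hold more compounds than are shown below. What is called first, only, known or untested is meant among the compounds shown, and "the series" means these compounds.

For the measured compounds named here, compound 1 `COc1cc(/C(Cl)=C/C=C(\C#N)C(=O)c2c[nH]c3ccccc23)cc(OC)c1OC` is the only member of the series with a number in an ADME assay on Vero cells (Chlorocebus sabaeus) for cytotoxicity, read by sulforhodamine B assay, with a stated time of 48 h (a lower number here means a stronger inhibitor of growth, a higher number a weaker inhibitor of growth), where compound 1 gives 16200 nM. Compound 2 `COc1ccc(/C(Cl)=C/C=C(\C#N)C(=O)c2c(C)[nH]c3ccccc23)cc1` has no result in this assay, recorded as "not determined" (no result reported), and compound 3 `COc1ccc(/C(Cl)=C/C=C(\C#N)C(=O)c2c[nH]c3ccccc23)cc1OC` likewise stands at "not determined" (no result reported); neither offers a comparison. Compound 4 `COc1cc(/C(Cl)=C/C=C(\C#N)C(=O)c2c(C)[nH]c3ccccc23)cc(OC)c1OC` differs from compound 1 by methyl in place of hydrogen on an aromatic carbon. Going by the values given here, no step between two measured compounds exists, so the weight of this change is untested. The expected step is a 1.2-fold lower number from compound 1 to compound 4 (0.06 log units; within the scatter), a change not beyond the usual scatter, with weak growth inhibition retained. Compound 4 is estimated at 14000 nM, within a range from 6000 nM to 35000 nM.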

Compound 4, concentration for 50% growth inhibition: 12400 nM
Beside the measured number, compound 4's estimate is 1.1-fold (0.05 log units) above it, and the stated range covers the measured number.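

In this assay, for the compounds shown here, the change from 1H-indol-3-yl to 2-methyl-1H-indol-3-yl gives a 1.3-fold lower number from compound 1 to compound 4 (0.12 log units; within the scatter) and provides the first measured step. At this position next to the ring nitrogen, methyl is tolerated without a change beyond the scatter, on the core of compound 1 at least. Nothing available explains this result. Steps involving compound 2 or compound 3 cannot be read, so whether methyl behaves alike on other cores stays open. Also open, from the compounds shown here alone, is whether an ethyl, an amine or a carboxylic acid here would leave the number equally undisturbed.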